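Swapping the Fluorophenyl Acyl Group on a Carboxamide

A few compounds are considered here, and "the series" means these few. Any claim that something is new, unique, unknown or untested is made for them only; others in the source may bear on it.

Compound 1, `CCOC(=O)c1sc(-c2cccc(NC(=O)c3cccc(F)c3)c2)nc1Nc1ccc(N2CCN(C)CC2)cc1`, gives 82.8% in a functional assay on Raji cells (Homo sapiens) for antiproliferative activity, read by CCK-8 assay, with a stated time of 72 h, tested at 40 uM; on this read-out lower numbers stand for less inhibition and higher numbers for more inhibition at the one concentration tested (going by the name of the read-out).
Compound 2, `CN1CCN(c2ccc(Nc3nc(-c4cccc(NC(=O)c5cccc(F)c5)c4)sc3C(=O)O)cc2)CC1`, gives 76.3% in this assay.
Compound 3, `CN1CCN(c2ccc(Nc3nc(-c4cccc(NC(=O)c5cccc(F)c5)c4)sc3C(N)=O)cc2)CC1`, gives 2.78% in this assay.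

Compound 3 stands lowest of the three numbers. Its nearest neighbour is compound 2, reached by a number 73.5 percentage points lower from compound 2 to compound 3 (beyond the scatter), and the gap to the furthest number is a number 80 percentage points lower from compound 1 to compound 3 (beyond the scatter), both large and beyond the scatter. The ester and the acid, by contrast, are separated only by a number 6.5 percentage points lower from compound 1 to compound 2 (within the scatter), which lies within the scatter.

Compound 4, `CN1CCN(c2ccc(Nc3nc(-c4cccc(NC(=O)[C@H]5CC[C@H](C)CC5)c4)sc3C(N)=O)cc2)CC1`, differs from compound 3 in one place: 4-methylcyclohexyl in place of 3-fluorophenyl on a carbonyl carbon. Going by the values given here, none of the measured steps touches this part of the molecule; all three concern the group on the carbonyl carbon of the shared core, and compound 4 keeps the primary carboxamide of compound 3 unchanged. Among the compounds with values here, there is therefore no measured step that speaks directly to the change from compound 3 to compound 4, and the only anchor is the low number of compound 3 itself.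

Compound 4 is accordingly expected to remain close to compound 3, with a step of about a number 7.2 percentage points higher from compound 3 to compound 4 (within the scatter), not clearly beyond the scatter. The estimate for compound 4 in this assay is 10%, within a range from 0% to 40%.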

Compound 4, a percentage reported as inhibition, at one concentration (the size of the read-out at that concentration, not a potency): 22.4%
The estimate for compound 4 lay 12.4 percentage points below the measured number; measured number inside the range.
By their numbers in this assay, from the lowest: compound 3; then compound 4; then compounds 2 and 1 (each within the scatter of the next).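

Going by these compounds alone, the earlier steps all changed the group on the carbonyl carbon of the shared core, so compound 4 gives the first reading at the other carbonyl carbon, the one whose other neighbour is an amide-type nitrogen. In this assay, 4-methylcyclohexyl in place of 3-fluorophenyl there gives a number 19.6 percentage points higher from compound 3 to compound 4 (beyond the scatter), a modest step that shows this place can move the number even with the primary carboxamide kept. The heavy-atom count stays the same, but the swap removes the fluorine, replaces the aromatic ring with a non-aromatic one, and adds a methyl and two defined stereocentres all at once, and nothing available explains the step.

The compounds shown leave open whether a plain cyclohexyl or a 4-methylphenyl on this carbonyl carbon would read nearer compound 3 or compound 4, which would help separate the effect of the ring from that of the methyl. Also open, as far as these compounds go, is what the same swap would do with the ethyl ester of compound 1 or the carboxylic acid of compound 2 in place of the primary carboxamide.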